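Series notes: N-substitution on the amino group, A2b antagonism

This account rests on a few compounds, and the source may have more. Where it says the series, first, only, none or still open, it means among the compounds named here.

Measured so far:
compound 1 `CCn1c(-c2ccccc2)nc2c(N)ncnc21` 3020 nM
compound 2 `CCCn1c(-c2ccccc2)nc2c(N)ncnc21` 1040 nM
compound 3 `Cc1cccc(-c2nc3c(NC4CCCC4)ncnc3n2C)c1` 6030 nM

Among the compounds with values here, in a functional assay on CHO cells for antagonist activity at adenosine receptor A2b (Homo sapiens), read by 33P incorporation, with a stated time of 20 min (a higher number here means a weaker inhibitor, a lower number a stronger inhibitor), compound 2 stands lowest of the three; the step of a 2.9-fold lower number from compound 1 to compound 2 (0.46 log units; beyond the scatter) is the only single change measured. Compound 4 `CCCn1c(-c2ccccc2)nc2c(NC3CCOC3)ncnc21` differs from compound 2 by oxolan-3-yl in place of hydrogen on a nitrogen on an aromatic ring, that is amino to (oxolan-3-yl)amino. Within the data shown here, no measured step tests this change directly. Compound 3 carries a cyclopentyl on the same nitrogen and gives a higher number than compound 2 in this assay, but it differs from compound 2 in two further places, so its value bears only loosely. A modest rise, or none beyond the scatter, is expected; the estimated step is a 2.4-fold higher number from compound 2 to compound 4 (0.38 log units; beyond the scatter). Compound 4 is thus expected at 2500 nM, within 600 nM to 10000 nM.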

Compound 4, inhibition constant: 9080 nM
Beside the measured number, compound 4's estimate is 3.6-fold (0.56 log units) below it, and the stated range covers the measured number.
By their numbers in this assay, from the lowest: compound 2; then compounds 1, 3 and 4 (each within the scatter of the next, the first and the last beyond it).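

In this assay, the amino nitrogen is now tested directly on an otherwise unchanged core: oxolan-3-yl in place of hydrogen gives an 8.7-fold higher number from compound 2 to compound 4 (0.94 log units; beyond the scatter). Within the data shown here, the only earlier single change lay on the chain, so this is the first sign that this nitrogen is sensitive to substitution, with the unsubstituted amino group of compound 2 giving the lower number. Nothing available explains the step.

From the compounds shown here alone, whether the rise belongs to oxolan-3-yl itself or to any substituent on this nitrogen remains open. Methyl or an open 2-methoxyethyl chain at the same place would separate the two.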